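A few compounds are considered here, and "the series" means these few. Any claim that something is new, unique, unknown or untested is made for them only; others in the source may bear on it.

In a functional assay on MT4 cells (Homo sapiens) for cytotoxicity, read by MTT assay (a lower number here means that less compound is tolerated, a higher number that more compound is tolerated), compound 1 `Cc1c(O)nc(SCc2ccc(O)cc2)nc1Cc1c(Cl)cccc1Cl` gives 41000 nM. Compound 2 `Cc1c(O)nc(SCc2ccc(Cl)cc2)nc1Cc1c(Cl)cccc1Cl` gives only a limit of the assay, > 59000 nM. Compound 3 `Cc1c(O)nc(SCc2ccccc2)nc1Cc1c(Cl)cccc1Cl` also gives only a limit, > 64000 nM, so it has no exact number. Compound 4 `Cc1c(O)nc(SCc2cccc(C#N)c2)nc1Cc1c(Cl)cccc1Cl` carries cyano in place of hydrogen on an aromatic carbon, meta to a large group, turning benzyl into 3-cyanobenzyl: cyano in place of hydrogen on an aromatic carbon. The measured steps on that ring are an at least 1.4-fold higher number from compound 1 to compound 2 (0.15 log units; that floor lies within the scatter), an at least 1.5-fold higher number from compound 1 to compound 3 (0.19 log units; that floor lies within the scatter) and a step that the two limits leave unreadable from compound 2 to compound 3. None of them shows a change beyond the scatter, so no step beyond the scatter is expected in this assay. The estimate amounts to an expected at least 1.1-fold lower number from compound 3 to compound 4 (0.06 log units; that floor lies within the scatter). For compound 4 the expected value is 55000 nM, within an estimated range of 25000 nM to 80000 nM.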

Compound 4, half-maximal cytotoxic concentration: > 60000 nM
Compound 4 gave a limit, no number; the forecaster's own chance of this, stated with the estimate: 65%; middle value at least 1.0-fold (0.03 log units) from the limit.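

The cyano group, meta to a large group, is the only nitrile among the compounds shown, and with it this assay still gives no exact number for compound 4. Compound 4 stays at a limit, so its steps to compound 2 and compound 3 cannot be read: the limit of > 60000 nM in this assay, at which 1 of the 4 values shown sits. Against the only exact number shown, the comparison reads an at least 1.4-fold higher number from compound 1 to compound 4 (0.16 log units; that floor lies within the scatter) and so shows no change beyond the scatter.

Going by these compounds, how far compound 2, compound 3 and compound 4 lie from one another stays open. So does whether an amine or a carboxylic acid at this place on the ring would give an exact number.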